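Swapping One Ring Stereocentre in a Cytotoxicity Series

A few compounds are considered here, and "the series" means these few. Any claim that something is new, unique, unknown or untested is made for them only; others in the source may bear on it.

Compound 1, `C=C(C)[C@@H]1C[C@@H](CC2(CC=C(C)C)C(=O)C(C(CC(=O)O)c3ccccc3)=C3O[C@H](C)[C@@H](C)C(=O)C3=C2O)C1(C)C`, and compound 2, `C=C(C)[C@@H]1C[C@@H](CC2(CC=C(C)C)C(=O)C3=C(O)[C@@H](C)[C@@H](C)OC3=C(C(CC(=O)O)c3ccccc3)C2=O)C1(C)C`, were both tested in a functional assay on Jurkat cells (Homo sapiens) for cytotoxicity; a higher number here means a weaker inhibitor, a lower number a stronger inhibitor. For compound 1 the result is only a limit of the assay, > 20 ug/mL. For compound 2 the result is likewise only a limit, > 20 ug/mL. Because (the limit of > 20 ug/mL in this assay, at which 2 of the 2 values shown sit), the two values cannot be told apart, and compound 2 stands only as a compound whose inhibition was too weak for a number to be read. Compound 3, `C=C(C)[C@@H]1C[C@@H](CC2(CC=C(C)C)C(=O)C3=C(O)[C@@H](C)[C@H](C)OC3=C(C(CC(=O)O)c3ccccc3)C2=O)C1(C)C`, is the compound still to be measured in this assay. Its difference from compound 2 is a single stereochemical one: the two compounds have the same atoms and bonds; at least one stereo element is drawn with a configuration in one of them and without one in the other: 1 of 6 stereo elements differ; a stereocentre at a saturated ring carbon is drawn R in compound 2 and S in compound 3. Within the data shown here, no step between measured compounds is available, so the weight of such a change is unknown here. The expected step is a step that the limit leaves unreadable from compound 2 to compound 3, nothing beyond the scatter. Compound 3 is expected to give about 30 ug/mL in this assay. Its estimated range runs from 10 ug/mL to 100 ug/mL.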

Compound 3, half-maximal inhibitory concentration: > 20 ug/mL
Compound 3: only a limit was reported; the forecaster's own chance of this, stated with the estimate: 75%; the middle value does not contradict the limit.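

No step can be read from compound 2 to compound 3 in this assay, because both results are only limits of the assay: the limit of > 20 ug/mL in this assay, at which 3 of the 3 values shown sit.

The compounds shown leave open whether a stereocentre drawn R or S at this saturated ring carbon changes inhibition at all, and how strong any of compounds 1, 2 and 3 really is.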